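From Methoxy to Isobutyl on the Shared Core

This account rests on a few compounds, and the source may have more. Where it says the series, first, only, none or still open, it means among the compounds named here.

Within the data shown here, in a functional assay on MDA-MB-231 cells (Homo sapiens) for antiproliferative activity, with a stated time of 4 days (a higher number here means a weaker inhibitor, a lower number a stronger inhibitor), compound 1 `COc1ccc(-c2[nH]c3ccc(OC)cc3c2C=O)cc1` gives 260 nM, the highest of the three numbers so far and the weakest inhibitor among them. Compound 2 `COc1ccc(-c2[nH]c3cc(Cl)ccc3c2C=O)cc1` gives 27 nM, and compound 3 `COc1ccc(-c2[nH]c3ccc(C(C)C)cc3c2C=O)cc1` gives 29 nM. Compound 4 `COc1ccc(-c2[nH]c3ccc(CC(C)C)cc3c2C=O)cc1` has not yet been measured. It carries isobutyl in place of methoxy on an aromatic carbon of the core of compound 1: isobutyl in place of methoxy on an aromatic carbon.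

Among the measured compounds shown here, the one measured step that bears directly on this change is a 9.0-fold lower number from compound 1 to compound 3 (0.95 log units; beyond the scatter), which has isopropyl in place of methoxy on an aromatic carbon and lies beyond the scatter. For the measured compounds named here, compound 2 differs from compound 1 in more than one place, so it offers no direct step. Going by the values given here, no measurement yet compares isobutyl with isopropyl, which leaves the size of the step uncertain. A drop of similar direction and somewhat smaller size is expected, estimated as a 5.8-fold lower number from compound 1 to compound 4 (0.76 log units; beyond the scatter). For compound 4 the estimated value is 45 nM, with an expected range of 14 nM to 150 nM.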

Compound 4, half-maximal inhibitory concentration: 72 nM
Beside the measured number, compound 4's estimate is 1.6-fold (0.20 log units) below it; measured number inside the range.
By their numbers in this assay, from the lowest: compounds 2 and 3 (each within the scatter of the next); then compound 4; then compound 1.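

In this assay, a second alkyl group in this place also improves on methoxy, with a 3.6-fold lower number from compound 1 to compound 4 (0.56 log units; beyond the scatter), so the gain seen with isopropyl is not unique to that group. The position also separates the two alkyl groups, since a 2.5-fold higher number from compound 3 to compound 4 (0.39 log units; beyond the scatter) shows that isobutyl keeps only part of that gain and that the change from isopropyl to isobutyl is not neutral here. Nothing available explains why these groups differ in this way.

The compounds shown leave open how a cyclopropyl group, a longer chain such as hexyl, or an amine would behave in this place. From the compounds shown here alone, with only methoxy, isopropyl and isobutyl compared on the shared core, it also remains unknown whether the higher number for isobutyl marks the start of a trend or is specific to that group.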